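The source may hold more compounds than are shown below. What is called first, only, known or untested is meant among the compounds shown, and "the series" means these compounds.

Measured so far:
compound 1 `N#Cc1cc(-c2nc(C(c3ccc(F)cc3)c3ccc(F)cc3)sc2CC(=O)O)ccc1F` gives 520 nM
compound 2 `O=C(O)Cc1sc(C(c2ccc(F)cc2)c2ccc(F)cc2)nc1-c1cc(F)nc(F)c1` gives 110 nM

Both compounds were tested in an in vitro functional assay on HEK285-7 cells for antagonist activity at prostaglandin D2 receptor 2 (Homo sapiens), read by BRET and beta-arrestin recruitment; on this read-out lower numbers stand for stronger inhibition and higher numbers for weaker inhibition. For the measured compounds named here, compound 2 has the lowest number of the two measured compounds, and the only measured step, a 4.7-fold lower number from compound 1 to compound 2 (0.67 log units; beyond the scatter), shows that the aromatic group attached to the shared core can shift the number beyond the scatter.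

Compound 3 `COc1cc(-c2nc(C(c3ccc(F)cc3)c3ccc(F)cc3)sc2CC(=O)O)ccn1` is the next compound to be measured. It differs from compound 2 in one place: 2-methoxypyridin-4-yl in place of 2,6-difluoropyridin-4-yl on an aromatic carbon. The six-membered aromatic ring with one nitrogen atom stays, but the two fluorine atoms are gone and a methoxy group comes in.

The step from compound 1 to compound 2 bears on this only loosely: it shows that swapping this aromatic group moved the number, but nothing measured tells how a methoxy group compares with the two fluorine atoms on the same ring. With so little to go on, the expected outcome for compound 3 is a change of about a 2.3-fold higher number from compound 2 to compound 3 (0.36 log units; beyond the scatter), with a wide range. Compound 3 is therefore estimated at 250 nM, somewhere between 70 nM and 900 nM.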

Compound 3, half-maximal inhibitory concentration: 380 nM
Compound 3: middle estimate off by 1.5-fold (0.18 log units), on the low side; measured number inside the range.
By their numbers in this assay, from the lowest: compound 2; then compounds 3 and 1 (each within the scatter of the next).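

In this assay, 2-methoxypyridin-4-yl in place of 2,6-difluoropyridin-4-yl gives a 3.5-fold higher number from compound 2 to compound 3 (0.54 log units; beyond the scatter) and so loses much of what compound 2 had gained, which shows that keeping a six-membered aromatic ring with one hetero atom at this position is not enough to hold the number of compound 2. The other new comparison, a 1.4-fold lower number from compound 1 to compound 3 (0.14 log units; within the scatter) in this assay and so inside the scatter, means that 2-methoxypyridin-4-yl and 3-cyano-4-fluorophenyl cannot be told apart here, although the first has a ring nitrogen and the second does not, so this ring nitrogen alone does not set the number. No measurement at hand explains why the two pyridine groups differ.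

Compound 3 differs from compound 2 by both the loss of the two fluorine atoms and the arrival of the methoxy group, so the compounds shown cannot say which of these matters more. A pyridine ring carrying a single fluorine atom, or one carrying an amine instead of the methoxy group, would be needed to pull those two parts apart.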